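This account rests on a few compounds, and the source may have more. Where it says the series, first, only, none or still open, it means among the compounds named here.

Compound 1 `COC(=O)C1=C(C)N(c2ccc(Cl)cc2)C(C)=C(C(=O)OC)C1[C@@H]1O[C@H]2OC(C)(C)O[C@H]2[C@@H]1OCc1ccccc1`: 4.22 ug/mL
Compound 2 `COC(=O)C1=C(C)N(c2ccc(Cl)cc2)C(C)=C(C(=O)OC)C1[C@@H]1O[C@H]2OC(C)(C)O[C@H]2[C@@H]1O`: 35.5 ug/mL
Compound 3 `COC(=O)C1=C(C)N(c2ccc(OC)cc2)C(C)=C(C(=O)OC)C1[C@@H]1O[C@H]2OC(C)(C)O[C@H]2[C@@H]1OC`: 18.6 ug/mL

In an ADME assay on J774.A1 cells (Mus musculus) for cytotoxicity, read by MTT assay, with a stated time of 72 h (on this read-out higher numbers stand for lower toxicity in this test and lower numbers for higher toxicity in this test), compound 3 gives 18.6 ug/mL, a value within the scatter of compound 2 and clearly higher than that of compound 1. Compound 4 `COC(=O)C1=C(C)N(c2ccc(Cl)cc2)C(C)=C(C(=O)OC)C1[C@@H]1O[C@H]2OC(C)(C)O[C@H]2[C@@H]1OC` differs from compound 3 by chloro in place of methoxy on an aromatic carbon. Within the data shown here, no measured step makes this change. Among the measured compounds shown here, the one measured step, an 8.4-fold higher number from compound 1 to compound 2 (0.92 log units; beyond the scatter), is hydrogen in place of benzyl on an oxygen on a saturated carbon, so it bears only indirectly, through the 4-chlorophenyl shared by compound 1, compound 2 and compound 4. The expected 1.2-fold lower number from compound 3 to compound 4 (0.07 log units; within the scatter) therefore stays within the scatter. For compound 4 the estimated value is 16 ug/mL, with an expected range of 7 ug/mL to 35 ug/mL.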

Compound 4, half-maximal cytotoxic concentration: 82.4 ug/mL
Beside the measured number, compound 4's estimate is 5.2-fold (0.71 log units) below it; measured number outside the range, above it.
By their numbers in this assay, from the lowest: compound 1; then compounds 3 and 2 (each within the scatter of the next); then compound 4.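

In this assay the change from 4-methoxyphenyl to 4-chlorophenyl gives a 4.4-fold higher number from compound 3 to compound 4 (0.65 log units; beyond the scatter), the first sign that this place on the aromatic ring affects the number. With 4-chlorophenyl held fixed, the group on the oxygen matters too: methyl in place of hydrogen gives a 2.3-fold higher number from compound 2 to compound 4 (0.37 log units; beyond the scatter), and methyl in place of benzyl gives a 20-fold higher number from compound 1 to compound 4 (1.29 log units; beyond the scatter). Nothing measured here explains these steps. On these data alone, whether an amine or a nitrile at the aromatic place would behave like chloro remains open, as does the effect of a longer chain, such as propyl, on the oxygen.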